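The source may report more compounds than this note shows. Statements on the series, on what has been measured and on what is new or still open speak of the compounds shown alone.

Compound 2 `COc1ccc(C2C(C#N)=C(N)OC(c3c[nH]c4ccccc34)=C2C#N)cc1OC` gives 26.1% in a functional assay, tested at 200 ug/mL; a lower number here means a weaker effect, a higher number a stronger effect of the compound at the concentration tested. Compound 1 `COc1cc(Br)c(C2C(C#N)=C(N)OC(c3c[nH]c4ccccc34)=C2C#N)cc1OC` gives 24.2% in this assay. The step of a number 1.9 percentage points higher from compound 1 to compound 2 (within the scatter) is within the scatter, so neither number stands apart from the other. Compound 3 `N#CC1=C(N)OC(c2c[nH]c3ccccc23)=C(C#N)C1c1ccccc1Cl` remains to be measured in this assay. Its change from compound 2 is 2-chlorophenyl in place of 3,4-dimethoxyphenyl on a saturated ring carbon. For the measured compounds named here, no measured step exchanges the group on the saturated ring carbon; the one step in hand, hydrogen in place of bromo, stayed within the scatter, so compound 3 is expected to show a number 1.1 percentage points lower from compound 2 to compound 3 (within the scatter), nothing beyond the scatter. Compound 3 is therefore estimated at 25%, with a range from 10% to 42%.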

Compound 3, a percentage reported as activity, at one concentration (the size of the read-out at that concentration, not a potency): 14.5%
Compound 3: middle estimate off by 10.5 percentage points, on the high side; measured number inside the range.
By their numbers in this assay, from the lowest: compounds 3, 1 and 2 (each within the scatter of the next, the first and the last beyond it).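

The group on the saturated ring carbon matters in this assay: 2-chlorophenyl in place of 3,4-dimethoxyphenyl gives a number 11.6 percentage points lower from compound 2 to compound 3 (beyond the scatter), whereas the earlier step, hydrogen in place of bromo, stayed within the scatter. For the compounds shown here, this is the first change to move the read-out beyond the scatter, though the step is modest. No available evidence explains the drop.

Since the step removes both methoxy groups and adds chlorine at once, their separate contributions remain unresolved. An unsubstituted phenyl at this position would help separate them, while an amine or carboxylic acid on the phenyl remains untested in the compounds shown.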